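The compounds below may be only part of what the source reports. "The series", "measured", "known", "first", "only" and "open" are said of these compounds alone.

Working notes on the series. Compound 1 `NS(=O)(=O)OC[C@@H]1C[C@@H](n2nnc3c(NCc4cccs4)ncnc32)C[C@@H]1O` gives 15.9 nM in an assay on a protein complex for inhibition of NEDD8 activating enzyme (Homo sapiens), read by HTRF, with a stated time of 2 h, in the presence of a further agent that is not named here; a lower number here means a stronger inhibitor, a higher number a weaker inhibitor. Compound 2 `NS(=O)(=O)OC[C@@H]1C[C@@H](n2nnc3c(N[C@@H]4c5ccccc5C[C@@H]4O)ncnc32)C[C@@H]1O` gives 2.28 nM in this assay, a change of a 7.0-fold lower number from compound 1 to compound 2 (0.84 log units; beyond the scatter). For the measured compounds named here, compound 3 `CN(C)[C@H]1Cc2ccccc2[C@H]1Nc1ncnc2c1nnn2[C@@H]1C[C@@H](COS(N)(=O)=O)[C@@H](O)C1` gives 207 nM, the highest of the three numbers so far, with the change a 91-fold higher number from compound 2 to compound 3 (1.96 log units; beyond the scatter); against compound 1 it also sits well above, beyond the scatter.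

Compound 4 `COCC(=O)N[C@H]1Cc2ccccc2[C@H]1Nc1ncnc2c1nnn2[C@@H]1C[C@@H](COS(N)(=O)=O)[C@@H](O)C1` is not yet measured. It differs from compound 3 by ((methoxymethyl)carbonyl)amino in place of dimethylamino on a saturated ring carbon. Going by the values given here, two measured steps bear on it. The step from compound 2 to compound 3 shows that replacing the hydroxy on this saturated ring carbon with dimethylamino costs heavily, so the group at this position matters; the step from compound 1 to compound 2 shows the fused bicyclic amine with its hydroxy is clearly favoured. Compound 4 restores a hydrogen-bond donor at that carbon, though in a larger group than hydroxy, so a partial recovery toward compound 2 is expected rather than a full one.

For compound 4 the expected step is a 4.1-fold lower number from compound 3 to compound 4 (0.62 log units; beyond the scatter) in this assay. The estimate for compound 4 is 50 nM, with a likely range from 10 nM to 300 nM.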

Compound 4, half-maximal inhibitory concentration: 170 nM
Compound 4: the middle estimate sits 3.4-fold (0.53 log units) below what was measured; low and high end bracket the measured number.
By their numbers in this assay, from the lowest: compound 2; then compound 1; then compounds 4 and 3 (each within the scatter of the next).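

In this assay, ((methoxymethyl)carbonyl)amino in place of dimethylamino on this saturated ring carbon gives a 1.2-fold lower number from compound 3 to compound 4 (0.09 log units; within the scatter), so the two groups cannot be told apart here, although only the entering group carries a hydrogen-bond donor. Against hydroxy on the same carbon, the same group gives a 75-fold higher number from compound 2 to compound 4 (1.87 log units; beyond the scatter), so among the three groups seen at this carbon, hydroxy alone goes with the low number, and having a hydrogen-bond donor in the group does not by itself bring that number back. Nothing measured here explains this difference between the groups.

Going by these compounds, whether a primary amine, a methoxy or a carboxylic acid on this carbon would come closer to hydroxy remains open. Also open, on these data alone, is how acetylamino, or a longer chain on the carbonyl, would read in this assay.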